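The source may hold more compounds than are shown below. What is called first, only, known or untested is meant among the compounds shown, and "the series" means these compounds.

Measured compounds:
compound 1, `CCOc1cc(NC(=O)NCc2cc(C)c(-c3cn(C)nc3C(F)(F)F)nn2)cc(C#N)n1`, 35 nM in a functional assay on HFL1 cells for antagonist activity at sphingosine 1-phosphate receptor 2 (Homo sapiens), read by ELISA, with a stated time of 24 h, in the absence of a further agent; on this read-out higher numbers stand for weaker inhibition and lower numbers for stronger inhibition
compound 2, `CCOc1cc(NC(=O)NCc2cc(C)c(-c3cn(C)nc3C(F)(F)F)nn2)cc(C)n1`, 242 nM
compound 3, `CCOc1nc(Cl)cc(NC(=O)NCc2cc(C)c(-c3cn(C)nc3C(F)(F)F)nn2)c1C`, 15 nM

Compound 3 holds the lowest number of the three; compound 1 sits nearest, as a 2.3-fold lower number from compound 1 to compound 3 (0.37 log units; beyond the scatter) shows, and compound 2 furthest, as a 16-fold lower number from compound 2 to compound 3 (1.21 log units; beyond the scatter) shows. The change from compound 1 to compound 2, a 6.9-fold higher number from compound 1 to compound 2 (0.84 log units; beyond the scatter), shows that the substitution pattern of the aryl group on the urea nitrogen moves this read-out by a modest to large amount.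

Compound 4, `CCOc1nc(C)cc(NC(=O)NCc2cc(C)c(-c3cn(C)nc3C(F)(F)F)nn2)c1Cl`, differs from compound 3 only in that aryl group: 3-chloro-2-ethoxy-6-methylpyridin-4-yl in place of 6-chloro-2-ethoxy-3-methylpyridin-4-yl on an amide-type nitrogen. The two have the same atoms, joined differently. Among the compounds with values here, no measured step alters the arrangement of chloro and methyl on this ring while keeping the ethoxy, so no step bears on it directly; the measured steps only indicate that such ring changes can be modest or large. The outcome is therefore uncertain in direction, with a modest move or none beyond the scatter taken as the expectation. Compound 4 is estimated at 30 nM, range 10 nM to 100 nM, meaning an expected step of a 2.0-fold higher number from compound 3 to compound 4 (0.30 log units; within the scatter).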

Compound 4, half-maximal inhibitory concentration: 26 nM
Compound 4: middle estimate off by 1.2-fold (0.06 log units), on the high side; the range from low to high includes it.
By their numbers in this assay, from the lowest: compounds 3, 4 and 1 (each within the scatter of the next, the first and the last beyond it); then compound 2.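

In this assay, 3-chloro-2-ethoxy-6-methylpyridin-4-yl in place of 6-chloro-2-ethoxy-3-methylpyridin-4-yl on the amide-type nitrogen leaves the two compounds unresolved (a 1.7-fold higher number from compound 3 to compound 4 (0.24 log units; within the scatter)), so for this pair the arrangement of chloro and methyl on the ring does not separate them. Chloro in place of hydrogen on an aromatic carbon is a single change that moves the read-out beyond the scatter (a 9.3-fold lower number from compound 2 to compound 4 (0.97 log units; beyond the scatter)), which the step from compound 2 to compound 3, with chloro and methyl both altered, could not isolate. Chloro and methyl on this ring also match the nitrile-bearing 2-cyano-6-ethoxypyridin-4-yl group within the scatter (a 1.3-fold lower number from compound 1 to compound 4 (0.13 log units; within the scatter)), and no measurement at hand explains any of these steps.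

Open, on these data alone, is whether bromo or an amine can stand where chloro stands on the ring. Also open, as far as these compounds go, is how a longer chain such as propoxy in place of ethoxy would read.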